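A Fused Core Gains an Aminophenyl Group

The source may hold more compounds than are shown below. What is called first, only, known or untested is meant among the compounds shown, and "the series" means these compounds.

Compound 1 `COC(=O)c1sc2cc(-c3cccs3)cnc2c1N` is one of two compounds tested in a functional assay on MCF7 cells (Homo sapiens) for inhibition, read by sulforhodamine B assay, with a stated time of 48 h; on this read-out higher numbers stand for weaker inhibition of growth and lower numbers for stronger inhibition of growth. In this assay, for the measured compounds named here, compound 1 gives 26900 nM, which is the only plain number in this small set; the other result is the limit of > 150000 nM in this assay, at which 1 of the 2 values shown sits. Compound 2 `COC(=O)c1sc2cc(-c3ccc(C(C)=O)cc3)cnc2c1N` reaches only a limit of the assay, > 150000 nM, so no number can be stated for it. Going by the values given here, with no pair of measured compounds differing in just one place, no measured step is available to lean on.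

Compound 3 `COC(=O)c1sc2cc(-c3ccccc3N)cnc2c1N` is not yet measured. It differs from compound 1 in one place: 2-aminophenyl in place of thiophen-2-yl on an aromatic carbon. Both groups hang from the same fused core. Whether the five-membered sulfur-containing ring or the six-membered carbon ring with its amine gives tighter growth inhibition cannot be read from the two values shown, so the expectation is cautious, leaning toward no change beyond the scatter or a modest loss. Compound 3 is expected to give 35000 nM, with a likely range from 8000 nM to 150000 nM. That estimate implies a step of a 1.3-fold higher number from compound 1 to compound 3 (0.11 log units; within the scatter), expected to sit within the usual scatter.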

Compound 3, concentration for 50% growth inhibition: 4200 nM
Compound 3: the middle estimate sits 8.3-fold (0.92 log units) above what was measured; the measured number lies below the stated range.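

In this assay, the change to 2-aminophenyl gives a 6.4-fold lower number from compound 1 to compound 3 (0.81 log units; beyond the scatter) and so stronger inhibition of growth. For the compounds shown here, this is the first readable evidence that the group on this aromatic carbon, two atoms from the ring nitrogen, can shift the result by more than the usual scatter while the shared core stays the same. Compound 2 gives only a limit, so any step to or from it cannot be read: the limit of > 150000 nM in this assay, at which 1 of the 3 values shown sits.

The change replaces a five-membered sulfur-containing ring with a six-membered carbon ring and also adds an amine, so the result does not show which of these matters, and a plain phenyl group or a 2-hydroxyphenyl group at this carbon would help separate the two. Nothing shown here gives a measured reason for the step, and the one readable step cannot establish a wider pattern across other groups at this position.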